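Ortho-substituted aryl diaminotriazines in a lipophilicity assay

The compounds below may be only part of what the source reports. "The series", "measured", "known", "first", "only" and "open" are said of these compounds alone.

Compound 1 `Nc1nc(N)nc(-c2cc(F)ccc2Cl)n1`: 1.38
Compound 2 `Nc1nc(N)nc(-c2ccccc2Br)n1`: 1.26
Compound 3 `CCOc1ccccc1-c1nc(N)nc(N)n1`: 1.03

Three compounds share the core shown and have been measured in a physicochemical assay for lipophilicity; a lower number here means a more polar compound, a higher number a more lipophilic compound. Compound 3 stands lowest of the three; compound 2 is nearest, a number 0.23 log units lower from compound 2 to compound 3 (within the scatter), and compound 1 is furthest, its value lying beyond the scatter above that of compound 3.

The unmeasured compound 4 `Nc1nc(N)nc(-c2ccccc2Cl)n1` differs from compound 3 in one place: chloro in place of ethoxy on an aromatic carbon. Within the data shown here, one measured step bears on this, the exchange of bromo for ethoxy that gave a number 0.23 log units lower from compound 2 to compound 3 (within the scatter); compound 4 reverses a change of that kind, with chloro rather than bromo entering. Compound 1, which also carries chloro on the aromatic ring, gives 1.38, and compound 2 gives 1.26. From these a small rise in this assay is expected, a number 0.17 log units higher from compound 3 to compound 4 (within the scatter), likely within the scatter.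

Compound 4 is therefore estimated at 1.2, in the range 0.95 to 1.45.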

Compound 4, partition coefficient: 1.19
Compound 4: the middle estimate sits 0.01 log units above what was measured; low and high end bracket the measured number.
By their numbers in this assay, from the lowest: compounds 3, 4, 2 and 1 (each within the scatter of the next, the first and the last beyond it).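

In this assay the exchange at this position gives a number 0.16 log units higher from compound 3 to compound 4 (within the scatter) when chloro, with one heavy atom, replaces ethoxy, with three heavy atoms, so this difference in size of the group leaves the read-out inside the scatter. Chloro in place of bromo gives a number 0.07 log units lower from compound 2 to compound 4 (within the scatter) at the same aromatic carbon, so these two halogens cannot be told apart here, and the step of a number 0.19 log units lower from compound 1 to compound 4 (within the scatter) shows that removing fluoro from elsewhere on the ring likewise stays inside the scatter. Nothing measured on hand explains why these steps are so small.

Going by these compounds, whether a group of another kind at this position, such as an amine, a carboxylic acid or a longer chain, would give a step beyond the scatter remains open. So does whether any such step would hold with fluoro also on the ring.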